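Three Amide Analogs Measured, a Fourth Awaiting Its Number

A few compounds are considered here, and "the series" means these few. Any claim that something is new, unique, unknown or untested is made for them only; others in the source may bear on it.

Compounds measured so far:
compound 1, `O=C(Nc1cccc(-c2oc3cc(-c4ccc(F)cc4)ccc3c(=O)c2O)c1)c1ccccc1F`, 7570 nM
compound 2, `COc1ccc(C(=O)Nc2cccc(-c3oc4cc(-c5ccc(F)cc5)ccc4c(=O)c3O)c2)cc1`, 6250 nM
compound 3, `O=C(Nc1cccc(-c2oc3cc(-c4ccc(F)cc4)ccc3c(=O)c2O)c1)c1ccc(Cl)cc1`, 4730 nM

All three were tested in a functional assay on MCF7 cells (Homo sapiens) for antiproliferative activity, read by CCK-8 assay, with a stated time of 72 h; on this read-out higher numbers stand for weaker inhibition and lower numbers for stronger inhibition. Within the data shown here, compound 3 gives the lowest of the three numbers, but its steps to the others are small: a 1.3-fold lower number from compound 2 to compound 3 (0.12 log units; within the scatter) and a 1.6-fold lower number from compound 1 to compound 3 (0.20 log units; within the scatter), both within the scatter, so no compound can be called stronger or weaker than another on these data.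

Compound 4, `COc1ccc(C(=O)Nc2cccc(-c3oc4cc(-c5ccc(F)cc5)ccc4c(=O)c3O)c2)c(F)c1`, has not yet been measured. It differs from compound 3 by the change (2-fluoro-4-methoxyphenyl in place of 4-chlorophenyl on a carbonyl carbon). Among the measured compounds shown here, the steps that bear on it are the replacement of 2-fluorophenyl by 4-methoxyphenyl, a 1.2-fold lower number from compound 1 to compound 2 (0.08 log units; within the scatter), and the replacement of methoxy by chloro, a 1.3-fold lower number from compound 2 to compound 3 (0.12 log units; within the scatter); compound 4 carries both the fluorine of compound 1 and the methoxy of compound 2 on its phenyl ring. Neither step moved the number beyond the scatter, and there is no measured pairing of the two substituents together to draw on.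

Compound 4 is therefore expected to land close to its neighbours, with a step of a 1.3-fold higher number from compound 3 to compound 4 (0.10 log units; within the scatter) that stays within the scatter. The estimate for compound 4 is 6000 nM, between 3000 nM and 12000 nM.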

Compound 4, half-maximal inhibitory concentration: 20000 nM
Estimate against measurement, compound 4: 3.3-fold (0.52 log units) below, and the stated range ends below it.
By their numbers in this assay, from the lowest: compounds 3, 2 and 1 (each within the scatter of the next); then compound 4.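

In this assay, among these compounds, the earlier changes at this position, on a carbonyl carbon whose other neighbour is an amide-type nitrogen, all stayed within the scatter, but 2-fluoro-4-methoxyphenyl in place of 4-chlorophenyl gives a 4.2-fold higher number from compound 3 to compound 4 (0.63 log units; beyond the scatter) and so separates two groups on this carbon for the first time. The two single additions point the same way: fluoro in place of hydrogen gives a 3.2-fold higher number from compound 2 to compound 4 (0.51 log units; beyond the scatter) on the methoxy-bearing ring, and methoxy in place of hydrogen gives a 2.6-fold higher number from compound 1 to compound 4 (0.42 log units; beyond the scatter) on the fluoro-bearing ring, so the ring carrying both substituents stands apart from all three rings carrying only one of them, and compound 4 is the weakest of the four here. Nothing measured alongside these numbers accounts for this shift.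

Going by these compounds, whether the weaker number belongs to this particular pairing of fluoro and methoxy, or would also follow if chloro were paired with fluoro on the same ring, remains open. How a carboxylic acid or a dimethylamino group on this phenyl ring would read in this assay also remains an open question.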